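Ethyl in Place of Chloro: From Compound 1 to Compound 4

A few compounds are considered here, and "the series" means these few. Any claim that something is new, unique, unknown or untested is made for them only; others in the source may bear on it.

Compound 1 `Nc1ccccc1NC(=O)/C=C/c1ccc(CSc2ccc(Cl)cc2)cc1` is one of three compounds tested in a functional assay on HeLa cells (Homo sapiens) for inhibition, read by CCK-8 assay, with a stated time of 72 h, tested at 8 uM; a higher number here means more inhibition of growth at the concentration tested, a lower number less inhibition of growth. Compound 1 gives 17.3%, the lowest of the three numbers. Compound 2 `CCc1ccc(SCc2ccc(C(=O)Nc3ccccc3N)cc2)cc1` gives 71%, and compound 3 `COc1ccc(SCc2ccc(C(=O)Nc3ccccc3N)cc2)cc1OC` gives 79.9%; both stand far above compound 1, beyond the usual scatter, but each differs from compound 1 in more than one place, so no single step can be read from them.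

Compound 4 `CCc1ccc(SCc2ccc(/C=C/C(=O)Nc3ccccc3N)cc2)cc1` has not yet been measured. It differs from compound 1 by one change only: ethyl in place of chloro on an aromatic carbon. Within the data shown here, no measured pair shows this change by itself, so its effect is not known from the data. Compound 2 also carries the ethyl group and gives a high number, though it differs from compound 1 elsewhere as well. The expected step is a number 14.7 percentage points higher from compound 1 to compound 4 (beyond the scatter), small to moderate and upward rather than large. Compound 4 is estimated to give 32% in this assay, with a range from 12% to 62%.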

Compound 4, percent growth inhibition at one concentration: 20.9%
Compound 4: the middle estimate sits 11.1 percentage points above what was measured; the measured number falls inside the stated range.
By their numbers in this assay, from the lowest: compounds 1 and 4 (each within the scatter of the next); then compounds 2 and 3 (each within the scatter of the next).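

In this assay, ethyl in place of chloro on this aromatic carbon gives a number 3.6 percentage points higher from compound 1 to compound 4 (within the scatter), so on the core of compound 1 this single change leaves the number where it was. Compound 4 carries the same ethyl group as compound 2 at 71%, which shows that the ethyl group by itself does not account for the high number of compound 2. Nothing measured here explains why this change has so little effect.

Still open, as far as these compounds go, is whether a different group at this place, such as an amine, a carboxylic acid or a longer chain like butyl, would move the number on this core. Also open, from the compounds shown here alone, is whether chloro and ethyl would read alike on the core of compound 2.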